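The compounds below may be only part of what the source reports. "The series", "measured", "known", "first", "only" and "open" are said of these compounds alone.

Working notes on the series: in a functional assay on PC-3 cells (Homo sapiens) for antiproliferative activity, read by MTT assay, with a stated time of 48 h (on this read-out higher numbers stand for weaker inhibition of growth and lower numbers for stronger inhibition of growth), compound 1 `CCN(Cc1ccc(C(=O)NO)cc1)c1ncc(-c2ccc(C)cc2)s1` gives 10300 nM, while compound 2 `Cc1ccc(OCCCCN(Cc2ccc(C(=O)NO)cc2)c2ncc(-c3ccc(C)cc3)s2)cc1` gives 1220 nM, the lower of the two numbers. Next in line is compound 3 `CCCCN(Cc1ccc(C(=O)NO)cc1)c1ncc(-c2ccc(C)cc2)s1`, which differs from compound 2 by hydrogen in place of 4-methylphenoxy on a saturated chain carbon, four bonds along the chain from a nitrogen on an aromatic ring. Cut one bond further out, the same change reads 3-(4-methylphenoxy)propyl to propyl. Going by the values given here, only one measured step bears on it: an 8.4-fold lower number from compound 1 to compound 2 (0.93 log units; beyond the scatter), with 2-(4-methylphenoxy)ethyl in place of hydrogen. Among the compounds with values here, that step is modest and changes chain length and the 4-methylphenoxy together, and no measured compound separates the two. A step to a higher number in this assay is therefore expected, probably beyond the scatter but smaller than the measured one. The expected step is a 3.7-fold higher number from compound 2 to compound 3 (0.57 log units; beyond the scatter). For compound 3 the estimate is 4500 nM, with an expected range of 1800 nM to 11000 nM.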

Compound 3, concentration for 50% growth inhibition: 6410 nM
For compound 3 the middle estimate is 1.4-fold (0.15 log units) below the measured one, within the range that was stated.
By their numbers in this assay, from the lowest: compound 2; then compounds 3 and 1 (each within the scatter of the next).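

In this assay, ethyl in place of hydrogen on a saturated chain carbon, two bonds along the chain from a nitrogen on an aromatic ring, gives a 1.6-fold lower number from compound 1 to compound 3 (0.21 log units; within the scatter), so the added chain alone does not separate from the scatter. Hydrogen in place of 4-methylphenoxy at the chain carbon four bonds along gives a 5.3-fold higher number from compound 2 to compound 3 (0.72 log units; beyond the scatter), so among these three compounds the stronger inhibition of growth in compound 2 goes with the 4-methylphenoxy and not with chain length alone. No evidence at hand bears on the reason for this step.

Going by these compounds, it remains open whether the 4-methylphenoxy could be replaced by plain phenoxy, a terminal amine or a carboxylic acid at the same chain end. On these data alone, how a longer chain carrying the 4-methylphenoxy would read also remains open.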